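From Fluoro to Methoxy at One Aromatic Carbon

This account rests on a few compounds, and the source may have more. Where it says the series, first, only, none or still open, it means among the compounds named here.

Three compounds share one core and differ only at a single aromatic carbon. Compound 1 `COC(=O)[C@@]1(C)CCC=C2[C@@H]1CC[C@@H](C)[C@]2(C)Cc1c[nH]c2ccccc12` gives 5000 nM in a functional assay on A549 cells (Homo sapiens) for inhibition, read by sulforhodamine B assay, with a stated time of 48 h; on this read-out higher numbers stand for weaker inhibition of growth and lower numbers for stronger inhibition of growth. Compound 2 `COC(=O)[C@@]1(C)CCC=C2[C@@H]1CC[C@@H](C)[C@]2(C)Cc1c[nH]c2ccc(Br)cc12` gives 15000 nM in this assay, and compound 3 `COC(=O)[C@@]1(C)CCC=C2[C@@H]1CC[C@@H](C)[C@]2(C)Cc1c[nH]c2ccc(F)cc12` gives 6200 nM. Compound 3 thus stands second highest of the three numbers: there is a 1.2-fold higher number from compound 1 to compound 3 (0.09 log units; within the scatter), whereas there is a 2.4-fold lower number from compound 2 to compound 3 (0.38 log units; beyond the scatter). Compound 4 `COC(=O)[C@@]1(C)CCC=C2[C@@H]1CC[C@@H](C)[C@]2(C)Cc1c[nH]c2ccc(OC)cc12` carries a (methoxy in place of fluoro on an aromatic carbon). Within the data shown here, the steps that bear on this change are a 3.0-fold higher number from compound 1 to compound 2 (0.48 log units; beyond the scatter), where bromo in place of hydrogen gave a weaker result, and a 1.2-fold higher number from compound 1 to compound 3 (0.09 log units; within the scatter), where fluoro changed little. Methoxy is the larger group, so a small move toward weaker inhibition is expected, a 1.3-fold higher number from compound 3 to compound 4 (0.11 log units; within the scatter). For compound 4 the expected value is 8000 nM, with a range from 3000 nM to 25000 nM.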

Compound 4, concentration for 50% growth inhibition: 2200 nM
The estimate for compound 4 lay 3.6-fold (0.56 log units) above the measured number, and the stated range ends above it.
By their numbers in this assay, from the lowest: compound 4; then compounds 1 and 3 (each within the scatter of the next); then compound 2.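

Before compound 4, a group on this aromatic carbon had only left the number in place or raised it; methoxy gives the first downward moves, with a 2.3-fold lower number from compound 1 to compound 4 (0.36 log units; beyond the scatter) and a 2.8-fold lower number from compound 3 to compound 4 (0.45 log units; beyond the scatter) against the fluoro and unsubstituted compounds. The choice of group here can therefore strengthen growth inhibition as well as weaken it, and a 6.8-fold lower number from compound 2 to compound 4 (0.83 log units; beyond the scatter) is the widest span yet seen at this carbon. No measurement offered here explains the methoxy result.

Going by these compounds, whether the gain comes with the oxygen alone or needs its methyl stays open. So does the outcome with a hydroxyl, an amine or a longer chain such as ethoxy on this carbon.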